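The source may hold more compounds than are shown below. What is called first, only, known or untested is meant among the compounds shown, and "the series" means these compounds.

Working notes on the series. Compound 2 `CCCCCC(=O)N1CCN(c2nc(N)c3cc(OC)c(OC)cc3n2)[C@@H]2CCCC[C@@H]21` stands highest of the two numbers recorded in a functional assay (strain Wistar) for antagonist activity at Alpha-1B adrenergic receptor (Rattus norvegicus), with a stated time of 30 min, in the presence of a further agent that is not named here (on this read-out lower numbers stand for lower potency and higher numbers for higher potency (the scale is a negative logarithm)), where compound 2 gives 7.99. Its nearest neighbour, compound 1 `CCCN(CCC)c1nc(N2CCN(C(=O)c3ccco3)[C@@H]3CCCC[C@@H]32)nc2cc(OC)c(OC)cc12`, differs from compound 2 at more than one place; in this assay compound 1 gives 7.17, a gap that lies beyond the scatter, and no single-point comparison between the two is available.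

Compound 3 `COc1cc2nc(N3CCN(C(=O)C(C)(C)C)[C@H]4CCCC[C@H]43)nc(N)c2cc1OC` has not yet been measured. It differs from compound 2 in one place only: tert-butyl in place of pentyl on a carbonyl carbon. For the measured compounds named here, since no step between measured compounds is known, the size of this change has no anchor. With only one point of reference, the expectation is a shift no larger than the scatter, a small loss being somewhat more likely than a gain. The expected step from compound 2 to compound 3 is a number 0.24 log units lower from compound 2 to compound 3 (within the scatter). Compound 3 is estimated at 7.75 in this assay, within 7.2 to 8.3.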

Compound 3, negative logarithm of the antagonist equilibrium constant: 8.26
Estimate against measurement, compound 3: 0.51 log units below; the measured number falls inside the stated range.
By their numbers in this assay, from the lowest: compound 1; then compounds 2 and 3 (each within the scatter of the next).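

For the compounds shown here, compounds 2 and 3 give the first step that can be read at one place: in this assay, tert-butyl in place of pentyl on a carbonyl carbon gives a number 0.27 log units higher from compound 2 to compound 3 (within the scatter) on a shared core. At this position, therefore, the two groups are not told apart by this read-out, although one is a pentyl chain and the other a tert-butyl group with one heavy atom fewer. No measurement at hand accounts for this result.

On these data alone, it remains open whether a longer chain such as octyl, or a group carrying an amine or a carboxylic acid, would also stay within the scatter of compound 2. Compound 1 differs from compound 2 at more than one place, so its number cannot be tied to the group on the carbonyl carbon.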